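This account rests on a few compounds, and the source may have more. Where it says the series, first, only, none or still open, it means among the compounds named here.

Measured compounds:

Compound 1, `O=c1[nH]c(=O)n(CCC(CO)CO)cc1C#Cc1ccc(Br)cc1`. In an ADME assay on BJ cells (Homo sapiens) for antiproliferative activity, read by MTT assay, with a stated time of 72 h (a higher number here means a weaker inhibitor, a lower number a stronger inhibitor), compound 1 gives > 100000 nM, which is a limit of the assay rather than a number.

Compound 2, `O=c1[nH]c(=O)n(CCC(CO)CO)cc1C#CCc1ccccc1`. In this assay compound 2 gives > 100000 nM, again a limit of the assay and not a number.

Among the compounds with values here, compound 2 therefore stands only at a limit in this assay, and the one other value shown, that of compound 1, is a limit as well. Within the data shown here, the single step between measured compounds, a step that the two limits leave unreadable from compound 1 to compound 2, is not readable in size, since both ends sit at the limit of > 100000 nM in this assay, at which 2 of the 2 values shown sit.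

The compound not yet measured is compound 3, `CC(C)(C)C#Cc1cn(CCC(CO)CO)c(=O)[nH]c1=O`. It differs from compound 2 by tert-butyl in place of benzyl on a triple-bonded carbon.

Among the measured compounds shown here, no measured step with a readable size bears on this change. What the data show is that a 4-bromophenyl group and a benzyl group on the triple-bonded carbon both leave the compound at the limit, and a tert-butyl group at the same place gives no ground to expect a departure from that. Compound 3 is accordingly expected to sit at the limit as well, a step from compound 2 to compound 3 of a step that the limit leaves unreadable from compound 2 to compound 3, that is none beyond the scatter. The estimate for compound 3 is 150000 nM, with a range from 50000 nM to 500000 nM.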

Compound 3, half-maximal inhibitory concentration: 58200 nM
For compound 3 the middle estimate is 2.6-fold (0.41 log units) above the measured one; measured number inside the range.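

With tert-butyl on the triple-bonded carbon, compound 3 gives 58200 nM in this assay, which shows that this place on the shared core can carry a group that yields a readable number, something neither 4-bromophenyl nor benzyl did. Tert-butyl in place of benzyl gives an at least 1.7-fold lower number from compound 2 to compound 3 (0.23 log units; that floor lies within the scatter), and tert-butyl in place of 4-bromophenyl gives an at least 1.7-fold lower number from compound 1 to compound 3 (0.23 log units; that floor lies within the scatter); each of these is only a floor, and the true size of either step stays unknown. Among the three compounds, the one with the group that has no ring is thus the only one with a number, while the two with a six-membered aromatic ring remain at a limit of the assay: the limit of > 100000 nM in this assay, at which 2 of the 3 values shown sit.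

As far as these compounds go, the step from compound 1 to compound 2 cannot be read, so any difference between benzyl and 4-bromophenyl remains open. Also open, from the compounds shown here alone, is how the number would respond to other groups on the triple-bonded carbon, such as a cyclopropyl ring, a longer chain such as n-hexyl, or a chain ending in an amine.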